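Alkyl substitution on the ring amide nitrogen: compound 3

The compounds below may be only part of what the source reports. "The series", "measured", "known", "first", "only" and "open" are said of these compounds alone.

Measured so far:
compound 1 `O=C1NC(=O)C2(CC2c2ccc3cccc(OCc4ccccc4)c3n2)N1` — 300 mg/kg
compound 2 `CCC(CO)N1C(=O)NC2(CC2c2ccc3cccc(OCc4ccccc4)c3n2)C1=O` — 30 mg/kg

Compound 2 stands lowest of the two numbers in a functional assay on the whole organism (strain Kunming) with Mus musculus as the target, in the maximal electroshock model, with a stated time of 0.5 h; on this read-out higher numbers stand for an effect only at larger amounts of compound and lower numbers for an effect already at smaller amounts; its nearest neighbour is compound 1, and the step of a 10-fold lower number from compound 1 to compound 2 (1.00 log units; beyond the scatter) lies beyond the scatter. Compound 3 `CCCCN1C(=O)NC2(CC2c2ccc3cccc(OCc4ccccc4)c3n2)C1=O` is not yet measured. It differs from compound 2 in one place: butyl in place of 1-(hydroxymethyl)propyl on an amide-type nitrogen in a ring. Among the measured compounds shown here, the only step in hand, a 10-fold lower number from compound 1 to compound 2 (1.00 log units; beyond the scatter), concerns the gain of a substituent on that nitrogen from hydrogen, not the exchange of one substituent for another; no pair shows the loss of the hydroxyl group from 1-(hydroxymethyl)propyl. The substituted nitrogen is kept in compound 3, so the number is expected to stay nearer compound 2 than compound 1, with a step of a 1.5-fold higher number from compound 2 to compound 3 (0.18 log units; within the scatter) that may not exceed the scatter. For compound 3 the estimate is 45 mg/kg, within 15 mg/kg to 150 mg/kg.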

Compound 3, minimum effective dose: 300 mg/kg
For compound 3 the middle estimate is 6.7-fold (0.82 log units) below the measured one, outside the stated range (above it).
By their numbers in this assay, from the lowest: compound 2; then compounds 1 and 3 (each within the scatter of the next).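

In this assay, a substituent on the amide-type nitrogen in a ring does not by itself go with a lower number: exchanging 1-(hydroxymethyl)propyl for butyl gives a clear loss (a 10-fold higher number from compound 2 to compound 3 (1.00 log units; beyond the scatter)), while butyl in place of hydrogen gives no difference (no change at the digits printed from compound 1 to compound 3 (within the scatter)). At this position the identity of the substituent therefore counts, not merely its presence, and among the three compounds only compound 2 stands apart. No measurement in hand bears on why the two substituents differ.

The compounds shown leave open whether the lower number of compound 2 goes with the hydroxyl group or with the branched chain of 1-(hydroxymethyl)propyl. A 1-methylpropyl or a 4-hydroxybutyl group on the same nitrogen would separate these two, and a 1-(aminomethyl)propyl group would show whether the hydroxyl can be exchanged for an amine.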